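The compounds below may be only part of what the source reports. "The series", "measured", "known", "first", "only" and "open" are said of these compounds alone.

Compounds measured in a functional assay on A2780 cells (Homo sapiens) for cytotoxicity, read by sulforhodamine B assay, with a stated time of 72 h; on this read-out higher numbers stand for weaker inhibition and lower numbers for stronger inhibition:
- compound 1, `CCCn1cc(S(=O)(=O)c2ccc(CNC(=O)N3Cc4ccncc4C3)cc2)cn1`, 7.3 nM
- compound 2, `CC(C)n1cc(S(=O)(=O)c2ccc(CNC(=O)N3Cc4ccncc4C3)cc2)cn1`, 11 nM
- compound 3, `O=C(NCc1ccc(S(=O)(=O)N2CCC[C@H](O)C2)cc1)N1Cc2ccncc2C1`, 150 nM

Compound 1 gives the lowest number of the three in this assay; compound 2 lies close to it, with a 1.5-fold higher number from compound 1 to compound 2 (0.18 log units; within the scatter), a difference that falls within the scatter, so the two cannot be ordered. Compound 3 stands far apart, with a 21-fold higher number from compound 1 to compound 3 (1.31 log units; beyond the scatter) and, from the other pyrazole, a 14-fold higher number from compound 2 to compound 3 (1.13 log units; beyond the scatter).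

The unmeasured compound 4, `CN1CCN(S(=O)(=O)c2ccc(CNC(=O)N3Cc4ccncc4C3)cc2)CC1`, differs from compound 1 at the sulfonyl sulfur: 4-methylpiperazin-1-yl in place of 1-propyl-1H-pyrazol-4-yl on a sulfonyl sulfur.

Among the measured compounds shown here, the steps that bear on this change are those from compound 1 and compound 2 to compound 3, in which a saturated nitrogen ring on the sulfonyl sulfur replaced a substituted pyrazole. Both steps were large and in the same direction. Compound 4 likewise carries a saturated nitrogen ring on the sulfonyl sulfur, though its ring is 4-methylpiperazin-1-yl rather than 3-hydroxypiperidin-1-yl, so a direct match is missing. Compound 4 is therefore expected to show a large step towards weaker inhibition, a 15-fold higher number from compound 1 to compound 4 (1.18 log units; beyond the scatter), because of a 21-fold higher number from compound 1 to compound 3 (1.31 log units; beyond the scatter). The estimate for compound 4 in this assay is 110 nM, with a range from 30 nM to 400 nM.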

Compound 4, half-maximal inhibitory concentration: 71 nM
The estimate for compound 4 lay 1.5-fold (0.19 log units) above the measured number; the range from low to high includes it.
By their numbers in this assay, from the lowest: compounds 1 and 2 (each within the scatter of the next); then compound 4; then compound 3.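

At the sulfonyl sulfur, a second saturated nitrogen ring, 4-methylpiperazin-1-yl, also gave weaker inhibition than either substituted pyrazole in this assay (a 9.7-fold higher number from compound 1 to compound 4 (0.99 log units; beyond the scatter); a 6.5-fold higher number from compound 2 to compound 4 (0.81 log units; beyond the scatter)), so among the compounds shown this loss is not confined to the 3-hydroxypiperidin-1-yl of compound 3. The two saturated rings are not interchangeable either, since the change between them gave a modest step towards stronger inhibition (a 2.1-fold lower number from compound 3 to compound 4 (0.32 log units; beyond the scatter)), and the result at this position therefore depends on which saturated ring is present as well as on the loss of the pyrazole. Nothing in the data at hand accounts for any of these differences.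

The compounds shown leave open whether the methyl group of compound 4 contributes to its difference from compound 3, which piperazin-1-yl without that methyl or morpholin-4-yl on the sulfonyl sulfur could help to test. They also leave open whether a different aromatic ring, such as pyridin-3-yl, would give numbers close to those of the pyrazoles or closer to those of the saturated rings.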